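Extending the Side Chain of Compound 2

The source may report more compounds than this note shows. Statements on the series, on what has been measured and on what is new or still open speak of the compounds shown alone.

Compound 1 `CCc1nn(CCCN2CCN(c3ccc(C)cc3)CC2)c(=O)c(N)c1C(C)=O`: in a functional assay on the whole organism (Abdomen, strain Swiss) for inhibition, with Mus musculus as the target, with stated times of 30 min, 10 min and 5 min, at a dose of 10 mg/kg by the oral route (on this read-out lower numbers stand for a weaker effect and higher numbers for a stronger effect at the one dose given), compound 1 gives 10%.
Compound 2 `C=Cc1c(CC)nn(CCCN2CCN(c3ccc(C)cc3)CC2)c(=O)c1N`: in this assay compound 2 gives 0%.

Among the compounds with values here, compound 2 holds the lowest of the two numbers, and its nearest neighbour is compound 1; the only measured step, a number 10 percentage points lower from compound 1 to compound 2 (within the scatter), lies within the scatter, so the two compounds cannot be told apart on this read-out. Compound 3 `C=Cc1c(CCCC)nn(CCCN2CCN(c3ccc(C)cc3)CC2)c(=O)c1N` differs from compound 2 by ethyl in place of hydrogen on a saturated chain carbon, two bonds along the chain from an aromatic carbon. Within the data shown here, no measured step touches this place: the single step on record, vinyl in place of acetyl, concerns a different group and was itself within the scatter. Nothing in the data therefore points to a shift in either direction, and since both measured compounds give little inhibition, compound 3 is expected to stay in the same low region. Compound 3 is estimated at 5%, between 0% and 20%, which means an expected step of a number 5 percentage points higher from compound 2 to compound 3 (within the scatter), not beyond the scatter.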

Compound 3, a percentage reported as inhibition, in the whole organism at one dose (the size of the read-out at that dose, not a potency): 0%
For compound 3 the middle estimate is 5 percentage points above the measured one; low and high end bracket the measured number.
By their numbers in this assay, from the lowest: compounds 2, 3 and 1 (each within the scatter of the next).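

Ethyl in place of hydrogen on a saturated chain carbon, two bonds along the chain from an aromatic carbon, gives the first measured step at this place, and in this assay it reads no change at the digits printed from compound 2 to compound 3 (within the scatter) on the vinyl compounds. So ethyl to butyl at this place, a change the earlier compounds did not touch, brings no effect that stands out from the scatter, and compound 2 at 0% leaves this read-out room only for a stronger effect, which butyl does not show. No measurement at hand offers an explanation for this result.

The compounds shown leave open whether a longer chain such as hexyl, or a chain ending in an amine or a carboxylic acid, would read differently at this place. They also leave open how butyl would read alongside the acetyl group of compound 1.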